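The source may hold more compounds than are shown below. What is called first, only, known or untested is meant among the compounds shown, and "the series" means these compounds.

The study covers three measured compounds on a shared core, all tested in a functional assay on SW480 cells (Homo sapiens) for cytotoxicity, read by MTT assay, with a stated time of 4 days; a lower number here means a stronger inhibitor, a higher number a weaker inhibitor. Compound 1 `C=C1C[C@]23C[C@@]1(O)CC[C@H]2c1ccc(O)c(C)c1[C@@H]3Cn1cc(-c2ccccn2)nn1` carries a free phenol and a pyridin-2-yl group on the triazole. In this assay compound 1 reaches only the limit of the assay, > 20000 nM. Compound 2 `C=C1C[C@]23C[C@@]1(O)CC[C@H]2c1ccc(OS(=O)(=O)c2ccc(C)cc2)c(C)c1[C@@H]3Cn1cc(-c2ccc(C)cc2)nn1` bears a tosylate on the phenol and a 4-methylphenyl group on the triazole. In this assay compound 2 likewise gives only a limit, > 20000 nM. Compound 3 `C=C1C[C@]23C[C@@]1(O)CC[C@H]2c1ccc(OS(=O)(=O)c2ccc(C)cc2)c(C)c1[C@@H]3Cn1cc(-c2ccccc2)nn1` differs from compound 2 by hydrogen in place of methyl on an aromatic carbon. In this assay compound 3 also stands at a limit, > 20000 nM. The step that the two limits leave unreadable from compound 2 to compound 3 is unreadable because of the limit of > 20000 nM in this assay, at which 3 of the 3 values shown sit. Compound 3 thus sits among values that are all limits, and no measured number places it above or below the others.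

Compound 4 `C=C1C[C@]23C[C@@]1(O)CC[C@H]2c1ccc(OS(=O)(=O)c2ccc(C)cc2)c(C)c1[C@@H]3Cn1cc(-c2ccccn2)nn1` arises from compound 3 through (pyridin-2-yl in place of phenyl on an aromatic carbon). Going by the values given here, no measured step bears directly on this change; the only measured step, a step that the two limits leave unreadable from compound 2 to compound 3, lies between two limits, and compound 1, which already carries the pyridin-2-yl group, also rests at a limit. Since every value shown sits at the limit (the limit of > 20000 nM in this assay, at which 3 of the 3 values shown sit), the expected step is estimated as a step that the limit leaves unreadable from compound 3 to compound 4, whose size is expected to remain unreadable. Compound 4 is expected to give 30000 nM in this assay, within 15000 nM to 80000 nM, most likely reported once more only as a limit.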

Compound 4, half-maximal inhibitory concentration: > 20000 nM
Compound 4 was reported as a limit (the forecaster's own chance of this, stated with the estimate: 85%); the middle value is on the limit's open side.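

No step can be read between compound 4 and compound 1, compound 2 or compound 3 in this assay, because each result is a limit and not a number: the limit of > 20000 nM in this assay, at which 4 of the 4 values shown sit.

The compounds shown leave open whether changing the group on the triazole or the tosylate on the phenol alters the read-out in this assay, and what number any of the four compounds would give.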